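Moving away from 4-(tert-butyl)phenyl in compound 3

The compounds below may be only part of what the source reports. "The series", "measured", "known", "first", "only" and "open" are said of these compounds alone.

In a functional assay for inhibition, with Homo sapiens as the target (a higher number here means weaker binding, a lower number tighter binding), compound 1 (`CSc1ccc(OC(C)(C)C2OCC(C/C=C\CCC(=O)O)C(c3cccnc3)O2)c([N+](=O)[O-])c1`) gives 4.47 nM, compound 2 (`Cc1ccc(C#N)c(OC(C)(C)C2OCC(C/C=C\CCC(=O)O)C(c3cccnc3)O2)c1`) gives 15.9 nM and compound 3 (`CC(C)(C)c1ccc(OC(C)(C)C2OCC(C/C=C\CCC(=O)O)C(c3cccnc3)O2)cc1`) gives 1910 nM, the highest number of the three. Compound 4 (`CC(C)(Oc1ccccc1F)C1OCC(C/C=C\CCC(=O)O)C(c2cccnc2)O1`) keeps the shared core and takes 2-fluorophenyl in place of 4-(tert-butyl)phenyl on an oxygen on a saturated carbon.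

For the measured compounds named here, two measured steps bear directly on this change: a 120-fold higher number from compound 2 to compound 3 (2.08 log units; beyond the scatter) and a 430-fold higher number from compound 1 to compound 3 (2.63 log units; beyond the scatter). Both are large. By comparison, a 3.6-fold higher number from compound 1 to compound 2 (0.55 log units; beyond the scatter) is modest. Going by the values given here, compound 2, with 2-cyano-5-methylphenyl, is the nearest guide by group name, but no measured compound carries fluorine, and three compounds support only a loose reading. A large move to a lower number is therefore expected, though compound 4 is not expected to reach the level of compound 1 at 4.47 nM. The expected step is a 32-fold lower number from compound 3 to compound 4 (1.50 log units; beyond the scatter). For compound 4 the estimated value is 60 nM, with an expected range of 12 nM to 350 nM.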

Compound 4, dissociation constant: 166 nM
Estimate against measurement, compound 4: 2.8-fold (0.44 log units) below, within the range that was stated.
By their numbers in this assay, from the lowest: compound 1; then compound 2; then compound 4; then compound 3.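

In this assay, the aryl group on this oxygen does not need a nitrile or a nitro group to lower the number well below that of compound 3 (a 12-fold lower number from compound 3 to compound 4 (1.06 log units; beyond the scatter)): 2-fluorophenyl, with fewer heavy atoms than 4-(tert-butyl)phenyl, is enough. It still falls short of both more heavily substituted rings (a 10-fold higher number from compound 2 to compound 4 (1.02 log units; beyond the scatter); a 37-fold higher number from compound 1 to compound 4 (1.57 log units; beyond the scatter)), so the order at this position now spans four distinct levels, with 2-fluorophenyl in the middle of the range. No measured evidence bears on the reason for these differences.

The change from compound 3 removes the tert-butyl group and adds fluorine together, leaving the share of each in the step unresolved. Going by these compounds, an unsubstituted phenyl ring on this oxygen would separate the two, and the response to a ring bearing an amine or a carboxylic acid remains open.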